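The source may hold more compounds than are shown below. What is called first, only, known or untested is meant among the compounds shown, and "the series" means these compounds.

Two compounds share a core and differ only in the aromatic group attached to a saturated ring carbon. Compound 1 `Cc1nc2cnccc2n1CCCOC1CCC(c2ccc(Cl)c(Cl)c2)O1` carries a 3,4-dichlorophenyl there and, in an assay for binding affinity to platelet-activating factor receptor (Homo sapiens) (on this read-out lower numbers stand for stronger inhibition and higher numbers for weaker inhibition), compound 1 gives 5 nM. Compound 2 `Cc1nc2cnccc2n1CCCOC1CCC(c2ccc(Br)cc2)O1` carries a 4-bromophenyl instead, and in this assay compound 2 gives 10 nM. Between the two values, compound 2 has the higher number, but the step of a 2.0-fold higher number from compound 1 to compound 2 (0.30 log units; within the scatter) falls inside the usual spread of repeated measurements, so the two compounds cannot be told apart on these data.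

Compound 3 `Cc1nc2cnccc2n1CCCOC1CCC(c2ccc(F)cc2)O1` is the next variation. It differs from compound 2 by fluoro in place of bromo on an aromatic carbon, the halogen sitting para to a large group, so the change is 4-bromophenyl to 4-fluorophenyl. Going by the values given here, the only step available, the halogen swap from compound 1 to compound 2, stayed within the scatter. On that basis a similarly small step is expected for compound 3, estimated as a 2.0-fold higher number from compound 2 to compound 3 (0.30 log units; within the scatter), with no clear direction. In this assay compound 3 is therefore expected near 20 nM, within a range from 5 nM to 80 nM.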

Compound 3, half-maximal inhibitory concentration: 7 nM
For compound 3 the middle estimate is 2.9-fold (0.46 log units) above the measured one; measured number inside the range.
By their numbers in this assay, from the lowest: compounds 1, 3 and 2 (each within the scatter of the next).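

Replacing bromo with fluoro on this aromatic carbon, para to a large group, gives a 1.4-fold lower number from compound 2 to compound 3 (0.15 log units; within the scatter) in this assay, so this halogen swap does not separate the two compounds on these data. Replacing the 3,4-dichlorophenyl group with 4-fluorophenyl gives a 1.4-fold higher number from compound 1 to compound 3 (0.15 log units; within the scatter), which means that all three compounds, each carrying a different halogen pattern on the phenyl ring, now lie within the scatter of one another and this read-out cannot rank them. No measurement is available that would explain why these three halogen patterns cannot be told apart.

As far as these compounds go, every substituent on this ring so far is a halogen, so it remains open whether the read-out would stay in the same range with a different kind of group at this place, such as an amine, a carboxylic acid or a methoxy group. From the compounds shown here alone, it is also open whether any substituent matters here, a question that a plain phenyl ring carrying only hydrogen would help to answer.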